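Second methyl on the aryl ring of compound 3

The compounds below may be only part of what the source reports. "The series", "measured", "known", "first", "only" and "open" are said of these compounds alone.

Compound 3 `COC(=O)C1=C(C)N=C(C)/C(=C(\O)OC)C1c1ccccc1C` holds the lowest number of the three measured in a functional assay (muscle tissue) with Cavia porcellus as the target; a lower number here means that less compound is needed, a higher number that more compound is needed for the effect: compound 3 gives 6.03 nM. Compound 1 `COC(=O)C1=C(C)N=C(C)/C(=C(\O)OC)C1c1ccccc1I` gives 46.8 nM, and compound 2 `COC(=O)C1=C(C)N=C(C)/C(=C(\O)OC)C1c1cc(Cl)cc(Cl)c1` gives 93.3 nM. The steps among them are a 7.8-fold lower number from compound 1 to compound 3 (0.89 log units; beyond the scatter), a 15-fold lower number from compound 2 to compound 3 (1.19 log units; beyond the scatter) and a 2.0-fold higher number from compound 1 to compound 2 (0.30 log units; within the scatter), so compound 3 stands apart from both others beyond the scatter.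

Compound 4 `COC(=O)C1=C(C)N=C(C)/C(=C(\O)OC)C1c1cc(C)ccc1C` differs from compound 3 by methyl in place of hydrogen on an aromatic carbon. Going by the values given here, no measured step touches this position. The step from compound 1 to compound 3 exchanges one group for another on an aromatic carbon that already carries a substituent, and the step from compound 2 to compound 3 exchanges the whole aryl group; neither shows what a further methyl at the place described does. With nothing to support a shift, the expected step for compound 4 in this assay is a 1.3-fold higher number from compound 3 to compound 4 (0.12 log units; within the scatter), within the scatter. Compound 4 is estimated at 8 nM, between 2.5 nM and 25 nM.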

Compound 4, half-maximal effective concentration: 100 nM
The estimate for compound 4 lay 13-fold (1.10 log units) below the measured number; measured number outside the range, above it.
By their numbers in this assay, from the lowest: compound 3; then compounds 1, 2 and 4 (each within the scatter of the next, the first and the last beyond it).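

The change from 2-methylphenyl to 2,5-dimethylphenyl gives a 17-fold higher number from compound 3 to compound 4 (1.22 log units; beyond the scatter) in this assay and shows that this aromatic carbon, meta to a large group and para to a methyl group, does not take even one added methyl without a large cost. The lead of compound 3 does not survive the change: the 2,5-dimethylphenyl group gives a 1.1-fold higher number from compound 2 to compound 4 (0.03 log units; within the scatter) against 3,5-dichlorophenyl, a step within the scatter, and a 2.1-fold higher number from compound 1 to compound 4 (0.33 log units; beyond the scatter) against 2-iodophenyl. No measured evidence in hand bears on the size of this step.

On these data alone, whether the step belongs to methyl itself or to any group on this carbon stays open, and a fluoro, a methoxy or an amine there would tell. Also open, as far as these compounds go, is whether the same added methyl gives a step of this size on the 2-iodophenyl group of compound 1.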